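The source may report more compounds than this note shows. Statements on the series, on what has been measured and on what is new or still open speak of the compounds shown alone.

Measured in a functional assay on HCT-116 cells (Homo sapiens) for inhibition, read by sulforhodamine B assay, with a stated time of 48 h; a lower number here means a stronger inhibitor, a higher number a weaker inhibitor:
compound 1 `CO[C@@H]1CC=C2NN(c3cc4ccccc4[nH]3)C(=O)C[C@]2(C)O1` gives 18300 nM
compound 2 `COc1ccc(N2NC3=CC[C@@H](OC)O[C@@]3(c3ccccc3)CC2=O)cc1` gives 11300 nM
compound 3 `COc1cc(OC)cc(N2NC3=CC[C@@H](OC)O[C@@]3(c3ccccc3)CC2=O)c1` gives 18100 nM

Compound 2 shows the lowest of the three numbers, but its gaps to compound 3 and to compound 1 both lie within the usual scatter, so the three compounds are not separable on these data. Compound 4 `CO[C@@H]1CC=C2NN(c3cncnc3)C(=O)C[C@]2(c2ccccc2)O1` has not yet been measured. Compared with compound 2 the change is pyrimidin-5-yl in place of 4-methoxyphenyl on an amide-type nitrogen in a ring. Among the compounds with values here, no measured pair in this set differs by a single change, so the size of this step is not anchored. With all three measured values close together, a step no larger than the scatter is expected, in either direction. For compound 4 the expected value in this assay is 16000 nM, range 5000 nM to 50000 nM, which means a step of a 1.4-fold higher number from compound 2 to compound 4 (0.15 log units; within the scatter).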

Compound 4, half-maximal inhibitory concentration: 9130 nM
Compound 4: middle estimate off by 1.8-fold (0.24 log units), on the high side, and the stated range covers the measured number.
By their numbers in this assay, from the lowest: compounds 4, 2, 3 and 1 (each within the scatter of the next).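

In this assay, within the data shown here, the first single-change pair gives a 1.2-fold lower number from compound 2 to compound 4 (0.09 log units; within the scatter), so pyrimidin-5-yl and 4-methoxyphenyl on the amide-type nitrogen in a ring are not separated. At this position, a six-membered aromatic ring of carbon only and one with 2 hetero atoms are therefore interchangeable in this read-out. No supporting evidence bears on this result.

Still open, on these data alone, is whether an amine or a carboxylic acid on this ring nitrogen would give a step beyond the scatter. Also open, as far as these compounds go, is whether replacing the phenyl group on the shared core with a longer chain would do so.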